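The source may hold more compounds than are shown below. What is called first, only, known or untested is meant among the compounds shown, and "the series" means these compounds.

Among the compounds with values here, in a functional assay on Ehrlich cells (Mus musculus) for cytotoxicity, read by trypan blue exclusion, with a stated time of 2 h, tested at 50 ug/mL (on this read-out lower numbers stand for a weaker effect and higher numbers for a stronger effect at the one concentration tested), compound 2 `Cc1ccc(C(=O)NC2=C(C#N)C(c3ccc(Cl)cc3Cl)C3=C(CCCC3=O)N2c2ccc(S(N)(=O)=O)cc2)cc1` gives 40%, the lowest of the two numbers known; compound 1 `CC(Cl)CC(=O)NC1=C(C#N)C(c2ccc(Cl)cc2Cl)C2=C(CCCC2=O)N1c1ccc(S(N)(=O)=O)cc1` gives 55% in this assay, and the step of a number 15 percentage points lower from compound 1 to compound 2 (beyond the scatter) is the only measured one. Compound 3 `N#CC1=C(NC(=O)/C=C/c2ccccc2)N(c2ccc(S(N)(=O)=O)cc2)C2=C(C(=O)CCC2)C1c1ccc(Cl)cc1Cl` differs from compound 2 by 2-phenylethenyl in place of 4-methylphenyl on a carbonyl carbon. Within the data shown here, no measured step exchanges one aromatic group for another on this carbonyl carbon, so the step from compound 1 to compound 2 bears on it only loosely, and compound 3 is expected to show a number 2 percentage points higher from compound 2 to compound 3 (within the scatter), a change not beyond the scatter. Compound 3 is therefore estimated at 42%, within 25% to 60%.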

Compound 3, a percentage reported as activity, at one concentration (the size of the read-out at that concentration, not a potency): 40%
Beside the measured number, compound 3's estimate is 2 percentage points above it; the range from low to high includes it.
By their numbers in this assay, from the lowest: compounds 2 and 3 (each within the scatter of the next); then compound 1.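

In this assay the read-out shows no change at the digits printed from compound 2 to compound 3 (within the scatter) with 2-phenylethenyl in place of 4-methylphenyl on the carbonyl carbon, so one group carrying an aromatic ring gives way to another without a shift beyond the scatter. Within the data shown here, the data also show a number 15 percentage points lower from compound 1 to compound 3 (beyond the scatter) with 2-phenylethenyl in place of 2-chloropropyl, a step matching in size the one from compound 1 to compound 2. Nothing given here explains this result.

The compounds shown leave open whether an amine, a carboxylic acid or a longer alkyl chain on this carbonyl carbon would read with compound 1 or with compound 2 and compound 3.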